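Chloro for Fluoro on the Aryl Ring of Compound 2

The source may report more compounds than this note shows. Statements on the series, on what has been measured and on what is new or still open speak of the compounds shown alone.

Of the compounds shown here, two of one shared core have been tested in a functional assay on MCF7 cells (Homo sapiens) for inhibition; a higher number here means a weaker inhibitor, a lower number a stronger inhibitor. Compound 1 `CC/C(=C(/c1ccc(/C=C/C(=O)O)cc1)c1cc2ccccc2[nH]1)c1ccccc1OC(F)(F)F` gives 206 nM in this assay. Compound 2 `CC/C(=C(/c1ccc(/C=C/C(=O)O)cc1)c1cc2ccccc2[nH]1)c1ccc(F)cc1Cl` gives 39 nM. Among the measured compounds shown here, the only measured step, a 5.3-fold lower number from compound 1 to compound 2 (0.72 log units; beyond the scatter), exchanges the entire aryl group on the chain carbon. Compound 2 thus holds the lowest number of the two, with compound 1 standing a modest distance higher.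

Compound 3 `CC/C(=C(/c1ccc(/C=C/C(=O)O)cc1)c1cc2ccccc2[nH]1)c1ccc(Cl)cc1Cl` differs from compound 2 by chloro in place of fluoro on an aromatic carbon. For the measured compounds named here, no measured step bears directly on this single halogen exchange; the step from compound 1 to compound 2 swaps the whole aryl group, so it shows only that this aryl group matters in this assay, not what one chloro for fluoro exchange does. Going by the values given here, with no closer precedent, the step from compound 2 to compound 3 is expected to be small, a 1.3-fold lower number from compound 2 to compound 3 (0.11 log units; within the scatter), and likely within the scatter. Compound 3 is therefore estimated at 30 nM in this assay, with a range from 10 nM to 90 nM.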

Compound 3, half-maximal inhibitory concentration: 11 nM
Beside the measured number, compound 3's estimate is 2.7-fold (0.44 log units) above it; the range from low to high includes it.
By their numbers in this assay, from the lowest: compound 3; then compound 2; then compound 1.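

In this assay, a single halogen exchange on this aromatic carbon, meta to a chloro group and para to a large group, is enough on its own to move the number beyond the scatter: a 3.5-fold lower number from compound 2 to compound 3 (0.55 log units; beyond the scatter). The earlier step replaced the whole aryl group, whereas this one leaves everything except the fluoro unchanged, so it places part of the aryl group's effect at this one position, and 2,4-dichlorophenyl now holds the lowest number of the three, with the whole-group comparison widening to a 19-fold lower number from compound 1 to compound 3 (1.27 log units; beyond the scatter). Nothing available on these compounds speaks to what lies behind this difference between chloro and fluoro.

The compounds shown leave open whether a bromo, a methyl or an amine on this aromatic carbon would carry the number lower still or raise it again. They also leave open whether the chloro for fluoro exchange would give a step of similar size if an amide stood in place of the carboxylic acid.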